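The compounds below may be only part of what the source reports. "The series", "measured", "known", "first", "only" and "open" are said of these compounds alone.

Measured compounds:
compound 1, `CCCCCCCCCCCCCCCCc1c(C)c(N(C)C)nc(C)c1O` — 84%
compound 2, `CCCCCCCCCCCCCCCCc1c(C)c(N2CCC2)nc(C)c1O` — 92%

Among the compounds with values here, in a functional assay on cells (Lymphocyte, Homo sapiens), read by trypan blue exclusion, with a stated time of 16 h, tested at 2.5 uM (a lower number here means a weaker effect, a higher number a stronger effect of the compound at the concentration tested), compound 1 gives 84%, one of only two numbers known here; the other belongs to compound 2, and the step of a number 8 percentage points higher from compound 1 to compound 2 (within the scatter) lies within the scatter, so the two compounds cannot be told apart on this read-out. The next compound is compound 3, `CCCCCCCCCCCCCCCCCCCc1c(C)c(N(C)C)nc(C)c1O`. It differs from compound 1 only along its long saturated chain: propyl in place of hydrogen on a saturated chain carbon, ten or more bonds along the chain from an aromatic carbon. Within the data shown here, no measured pair shows what lengthening this chain does; the single measured step concerns a different part of the molecule, where azetidin-1-yl replaces dimethylamino on an aromatic carbon, and even that step stayed within the scatter. With nothing pointing in either direction, the expected change in this assay is none beyond the scatter. Compound 3 is therefore estimated at 84%, with a range from 70% to 96%. The implied step no change at the digits printed from compound 1 to compound 3 (within the scatter) is expected to be small.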

Compound 3, a percentage reported as activity, at one concentration (the size of the read-out at that concentration, not a potency): 87%
Estimate against measurement, compound 3: 3 percentage points below; measured number inside the range.
By their numbers in this assay, from the lowest: compounds 1, 3 and 2 (each within the scatter of the next).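

In this assay, placing propyl on a saturated chain carbon gives a number 3 percentage points higher from compound 1 to compound 3 (within the scatter) and so the two compounds cannot be told apart. Within the data shown here, this is the first measured step at the long chain rather than at the dimethylamino group, and it shows that this far part of the chain can be extended by propyl without a change that rises above the scatter. Nothing measured here offers a reason for this result.

The compounds shown leave open whether a much shorter chain such as octyl, or a chain ending in an amine or a carboxylic acid, would keep the read-out at this level. They also leave open whether compounds that look alike at this single concentration would still differ at lower concentrations.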